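This account rests on a few compounds, and the source may have more. Where it says the series, first, only, none or still open, it means among the compounds named here.

Compound 1 `COc1c(OC(C)C)cc2occ(-c3csc4ccccc34)c(=O)c2c1OC(C)C` is the starting point in a functional assay on MDA-MB-231 cells (Homo sapiens) for antiproliferative activity, read by sulforhodamine B assay, with a stated time of 72 h (on this read-out lower numbers stand for stronger inhibition and higher numbers for weaker inhibition), where compound 1 gives > 10000 nM, which is a limit and not a number. Compound 2 `COc1c(OC(C)C)cc2occ(-c3csc4ccccc34)c(=O)c2c1O` gives > 10000 nM, also a limit. Compound 3 `COc1c(OC(C)C)cc2occ(-c3ccccc3)c(=O)c2c1OC(C)C` gives > 10000 nM, again a limit. Compound 1 therefore stands at the limit of > 10000 nM in this assay, at which 3 of the 3 values shown sit, so no order can be read among these compounds.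

Compound 4 `COc1c(OC(C)C)cc2oc(-n3cncn3)c(-c3csc4ccccc34)c(=O)c2c1OC(C)C` keeps the core of compound 1 and changes it in one place: 1H-1,2,4-triazol-1-yl in place of hydrogen on an aromatic carbon. The two measured changes are elsewhere on the molecule: a step that the two limits leave unreadable from compound 1 to compound 2, and a step that the two limits leave unreadable from compound 1 to compound 3. Among the measured compounds shown here, neither has a size that can be carried over to the new group, and no measured compound carries that group. With no measured gain or loss to build on, no firm direction can be predicted in this assay. The expected step is a number no higher from compound 1 to compound 4 (the limit leaves the size open), and this estimate stays close to the limit of compound 1 at > 10000 nM. For compound 4 the estimated value is 10000 nM, with an expected range from 3000 nM to 30000 nM.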

Compound 4, half-maximal inhibitory concentration: > 10000 nM
Compound 4 ended at the assay's limit; the forecaster's own chance of this, stated with the estimate: 75%; the middle value lies on the limit itself.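

Compound 4 gives > 10000 nM in this assay and this is a limit, not a number. Among the compounds shown here, compound 1 also sits at a limit, so no step between compound 1 and compound 4 can be read. The compounds shown leave open whether 1H-1,2,4-triazol-1-yl, or any other change to the core of compound 1, alters the activity at all.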